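The source may report more compounds than this note shows. Statements on the series, on what has been measured and on what is new or still open speak of the compounds shown alone.

Compounds in the series:
- Compound 1 `CCc1cccc2c(OC)c(-c3occ(C)c3C(=O)OC)ccc12`: 1.3 ug/mL
- Compound 2 `CCc1cccc2c(OC)c(-c3occ(C)c3C(=S)OC)ccc12`: 5.1 ug/mL
- Compound 3 `CCc1cccc2c(OC)c(-c3occ(C)c3C(=O)On3nnc4ccccc43)ccc12`: > 10 ug/mL (a limit)
- Compound 4 `CCOc1c(-c2occ(C)c2C(=O)OC)ccc2c(CC)cccc12`: not yet measured

All values come from a functional assay on KBVIN cells (Homo sapiens) for cytotoxicity, read by MTT assay, with a stated time of 72 h; on this read-out lower numbers stand for an effect already at smaller amounts and higher numbers for an effect only at larger amounts of compound. Compound 1 has the lower of the two actual numbers, and compound 2 is its nearest neighbour. Compound 3 gives a limit and no number: the limit of > 10 ug/mL in this assay, at which 1 of the 3 values shown sits.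

Compound 4 departs from compound 1 by a single change, methoxy to ethoxy: methyl in place of hydrogen on a saturated chain carbon bound to an oxygen on an aromatic ring.

Two measured steps start from compound 1: a 3.9-fold higher number from compound 1 to compound 2 (0.59 log units; beyond the scatter) and an at least 7.6-fold higher number from compound 1 to compound 3 (0.88 log units; beyond the scatter). Both moved to a higher number, so no change tried so far on compound 1 has lowered the number in this assay. Neither step alters the place changed in compound 4, so they give only weak guidance on direction and none on size for this methyl addition. With so little to go on, only a small shift is expected, leaning slightly towards a higher number.

The expected change is a 1.5-fold higher number from compound 1 to compound 4 (0.19 log units; within the scatter), a step not clearly separable from the scatter. The estimate for compound 4 is 2 ug/mL, with an expected range from 0.7 ug/mL to 6 ug/mL.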

Compound 4, concentration for half-maximal effect: 1.7 ug/mL
For compound 4 the middle estimate is 1.2-fold (0.07 log units) above the measured one, and the stated range covers the measured number.
By their numbers in this assay, from the lowest: compounds 1 and 4 (each within the scatter of the next); then compound 2. At a limit, above all of these: compound 3.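

Methoxy to ethoxy is the first change shown at this place, on a saturated chain carbon bound to an oxygen on an aromatic ring, and in this assay it reads as a 1.3-fold higher number from compound 1 to compound 4 (0.12 log units; within the scatter), so compound 4 cannot be told apart from compound 1 on this read-out. Both earlier steps from compound 1 left this place untouched and lay beyond the scatter, whereas this one does not, which shows that one added methyl here is accommodated without a clear shift in this assay. No measurement shown gives a reason for this outcome.

A single step describes only the move from methoxy to ethoxy, so the compounds shown do not reveal how far this tolerance extends, for instance to a longer chain such as propoxy, a branched isopropoxy group, a free hydroxyl or a chain ending in an amine. They also leave open whether the same methyl addition would behave alike on the other compounds in the series, where the ester has been altered.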